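Methoxy for fluoro on the shared core

The compounds below may be only part of what the source reports. "The series", "measured", "known", "first", "only" and "open" are said of these compounds alone.

The series shares one core. Compound 1 is `[O-]/[N+](=C\c1cn(-c2ccccc2)nn1)Cc1ccccc1` and compound 2 is `[O-]/[N+](=C\c1cn(-c2ccc(F)cc2)nn1)Cc1ccccc1`. In a functional assay on A549 cells (Homo sapiens) for inhibition, read by MTT assay, with a stated time of 24 h (on this read-out lower numbers stand for stronger inhibition and higher numbers for weaker inhibition), compound 1 gives only a limit, > 100000 nM. In this assay compound 2 likewise gives only a limit, > 100000 nM. The step from compound 1 to compound 2, fluoro in place of hydrogen on an aromatic carbon, is a step that the two limits leave unreadable from compound 1 to compound 2. Both values sit at the limit of > 100000 nM in this assay, at which 2 of the 2 values shown sit, so compound 2 stands at the limit of the assay with no number to place it more closely.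

Compound 3 is `COc1ccc(-n2cc(/C=[N+](\[O-])Cc3ccccc3)nn2)cc1`. It differs from compound 2 by methoxy in place of fluoro on an aromatic carbon. Within the data shown here, the only measured step, from compound 1 to compound 2, changes the same aromatic carbon but its size is not readable, so no measured step gives a size for this change in this assay. With both neighbours at the limit, a limit again is the expectation for compound 3. Compound 3 is estimated at 100000 nM, between 30000 nM and 300000 nM. The step this estimate means is expected to be a number no higher from compound 2 to compound 3 (the limit leaves the size open).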

Compound 3, half-maximal inhibitory concentration: > 100000 nM
Compound 3: no number, only a limit (the forecaster's own chance of this, stated with the estimate: 85%); the middle value sits exactly at the limit.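

No step among compound 1, compound 2 and compound 3 can be read in this assay, because all three compounds give only a limit: the limit of > 100000 nM in this assay, at which 3 of the 3 values shown sit.

The compounds shown leave open how hydrogen, fluoro and methoxy on this aromatic carbon compare, and whether any change to the shared core gives a measurable value.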